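This account rests on a few compounds, and the source may have more. Where it says the series, first, only, none or still open, it means among the compounds named here.

Measured so far:
compound 1 `COc1ccc(C(=O)/C=C/c2cc(OC)c(OC)cc2OC)cc1`, 60500 nM
compound 2 `COc1cc(OC)c(C(=O)/C=C/c2cc(OC)c(OC)cc2OC)c(OC)c1`, 96500 nM

Both were tested in a functional assay on SW982 cells (Homo sapiens) for inhibition, read by MTT assay, with a stated time of 72 h; a lower number here means a stronger inhibitor, a higher number a weaker inhibitor. Compound 1 gives 60500 nM, the lower of the two numbers, and compound 2 gives 96500 nM; the gap between them lies within the scatter, so neither can be called the stronger inhibitor. Compound 3 `COc1cc(OC)c(OC)cc1/C=C/C(=O)c1ccc(Br)cc1` is not yet measured. It differs from compound 1 in one place: bromo in place of methoxy on an aromatic carbon. Within the data shown here, no measured pair shows this change, so its effect is unknown; a step of modest size in either direction, or none beyond the scatter, is expected. On that basis compound 3 is expected to give 50000 nM, between 15000 nM and 160000 nM, which would mean a 1.2-fold lower number from compound 1 to compound 3 (0.08 log units; within the scatter) in this assay.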

Compound 3, half-maximal inhibitory concentration: 38200 nM
The estimate for compound 3 lay 1.3-fold (0.12 log units) above the measured number; the range from low to high includes it.
By their numbers in this assay, from the lowest: compounds 3, 1 and 2 (each within the scatter of the next, the first and the last beyond it).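

The change from 4-methoxyphenyl to 4-bromophenyl comes with a 1.6-fold lower number from compound 1 to compound 3 (0.20 log units; within the scatter) in this assay, so at this position the two groups cannot be told apart by this measurement. The methoxy, with its oxygen and hydrogen-bond acceptor, can therefore give way to a single bromine atom without a step beyond the scatter. No measurement is available that explains this result.

From the compounds shown here alone, whether an amine or a carboxylic acid at this position would move the number beyond the scatter remains open. So does the effect of a longer chain there.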